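The source may report more compounds than this note shows. Statements on the series, on what has been measured and on what is new or still open speak of the compounds shown alone.

Two compounds have been measured in a functional assay on MCF7 cells (Homo sapiens) for inhibition, read by MTT assay, with a stated time of 48 h, tested at 10 uM; a higher number here means more inhibition of growth at the concentration tested, a lower number less inhibition of growth:

compound 1 `O=C(/C=C/c1ccc(OCc2cn(Cc3ccc(Br)cc3)nn2)cc1)c1ccc(Br)cc1` — 23%
compound 2 `O=C(/C=C/c1ccc(OCc2cn(Cc3ccc(F)cc3)nn2)cc1)c1ccc(Br)cc1` — 37%

Compound 1 stands lowest of the two numbers; its nearest neighbour is compound 2, which differs only by fluoro in place of bromo on an aromatic carbon, and that exchange reads a number 14 percentage points higher from compound 1 to compound 2 (beyond the scatter).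

Compound 3 `COc1ccc(C(=O)/C=C/c2ccc(OCc3cn(Cc4ccc(Br)cc4)nn3)cc2)cc1` is the next compound to be measured. It differs from compound 1 by methoxy in place of bromo on an aromatic carbon. Going by the values given here, the one measured step replaces a halogen by another halogen, whereas the step to compound 3 replaces a halogen by a methoxy group on the (4-bromophenyl)carbonyl ring, so the measured step bears on it only loosely. It does show that a single small exchange at one aromatic carbon can move this assay by a modest amount, beyond the scatter. A change of similar size is therefore expected, with the direction uncertain, though a rise is judged somewhat more likely than a fall.

Compound 3 is estimated at 32% in this assay, within 10% to 55%, which would mean an expected step of a number 9 percentage points higher from compound 1 to compound 3 (within the scatter).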

Compound 3, percent growth inhibition at one concentration: 53%
The estimate for compound 3 lay 21 percentage points below the measured number; low and high end bracket the measured number.
By their numbers in this assay, from the lowest: compound 1; then compound 2; then compound 3.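

At the (4-bromophenyl)carbonyl end of compound 1, the exchange of bromo for methoxy reads in this assay as a number 30 percentage points higher from compound 1 to compound 3 (beyond the scatter). The earlier step, a number 14 percentage points higher from compound 1 to compound 2 (beyond the scatter), concerned the other bromo of compound 1 and a halogen-for-halogen exchange, so it gave no reading at this carbon; the new step shows that this position also responds, and that a group other than a halogen can be placed there with growth inhibition rising rather than being lost. No measurement is available that would explain the rise.

The compounds shown leave open whether the rise comes with the departure of bromo or the arrival of methoxy, and how a hydroxy group, an amine or a longer ethoxy chain would read on the same aromatic carbon. They also leave open whether methoxy at this carbon and fluoro on the other ring, taken together in one compound, would add up or would read no better than methoxy alone.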